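Compound 3 to compound 4: a 4-vinylphenyl exchange

The source may hold more compounds than are shown below. What is called first, only, known or untested is meant among the compounds shown, and "the series" means these compounds.

Values in a functional assay on MCF7 cells (Homo sapiens) for inhibition, read by CCK-8 assay, with a stated time of 48 h; a lower number here means a stronger inhibitor, a higher number a weaker inhibitor:
compound 1 `COc1cc(-c2ccnc3cc(-c4c[nH]c5ccccc45)nn23)cc(OC)c1OC`: 85 nM
compound 2 `COc1cc(-c2ccnc3cc(-c4ccc(C)cc4)nn23)cc(OC)c1OC`: 47 nM
compound 3 `COc1cc(-c2ccnc3cc(-c4cn(C)c5ccccc45)nn23)cc(OC)c1OC`: 95 nM

Compound 3 stands at the high end of this small set, but its only gap beyond the scatter is modest: a 2.0-fold higher number from compound 2 to compound 3 (0.31 log units; beyond the scatter). Its other gap, a 1.1-fold higher number from compound 1 to compound 3 (0.05 log units; within the scatter), lies within the scatter, so adding methyl on the aromatic nitrogen gives no separable change.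

The next compound is compound 4 `C=Cc1ccc(-c2cc3nccc(-c4cc(OC)c(OC)c(OC)c4)n3n2)cc1`, in which 4-vinylphenyl takes the place of 1-methyl-1H-indol-3-yl on an aromatic carbon: 4-vinylphenyl in place of 1-methyl-1H-indol-3-yl on an aromatic carbon.

The most relevant measured change is the exchange between 4-methylphenyl and 1-methyl-1H-indol-3-yl, a 2.0-fold higher number from compound 2 to compound 3 (0.31 log units; beyond the scatter). Read in reverse, it suggests a modest move toward a lower number in this assay, of similar or somewhat smaller size. Among the measured compounds shown here, the evidence is thin: the related exchange a 1.8-fold lower number from compound 1 to compound 2 (0.26 log units; within the scatter) stays within the scatter, and 4-vinylphenyl itself has no measured precedent on the shared core. The expected change is a 1.6-fold lower number from compound 3 to compound 4 (0.21 log units; within the scatter), which may not clear the scatter. For compound 4 the estimated value is 58 nM, with an expected range of 27 nM to 125 nM.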

Compound 4, half-maximal inhibitory concentration: 193 nM
For compound 4 the middle estimate is 3.3-fold (0.52 log units) below the measured one; measured number above the stated range.
By their numbers in this assay, from the lowest: compounds 2, 1 and 3 (each within the scatter of the next, the first and the last beyond it); then compound 4.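

Among the compounds shown here, at this aromatic carbon of the five-membered aromatic ring with 2 nitrogen, the largest step so far comes from a small exchange on the phenyl group: in this assay, vinyl in place of methyl gives a 4.1-fold higher number from compound 2 to compound 4 (0.61 log units; beyond the scatter), so the result for 4-methylphenyl does not carry over to 4-vinylphenyl. The exchanges against the two indolyl groups also clear the scatter, with a 2.3-fold higher number from compound 1 to compound 4 (0.36 log units; beyond the scatter) and a 2.0-fold higher number from compound 3 to compound 4 (0.31 log units; beyond the scatter), which places compound 4 at the high end of the four and shows that a phenyl ring at this place does not by itself set the number; the group it carries matters as well. Nothing available here accounts for the difference between the vinyl and methyl groups.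

From the compounds shown here alone, it remains open whether the step is tied to the double bond of the vinyl group, a question that ethyl in its place would address. Also open, going by these compounds, is how far the number moves when the vinyl group is replaced by a methoxy group, an amine or a carboxylic acid in this assay.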